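The compounds below may be only part of what the source reports. "The series", "measured", "known", "first", "only" and "open" are said of these compounds alone.

Three compounds share one core and differ only in the group carried on the amine nitrogen of the ring. Compound 1 `c1ccc(CN2CCN(CCCc3c[nH]c4ccc(-n5cnnc5)cc34)CC2)nc1` gives 0.4 nM in an assay on CHO cells for displacement of a labelled ligand from 5-hydroxytryptamine receptor 1D (Homo sapiens); on this read-out lower numbers stand for stronger inhibition and higher numbers for weaker inhibition. Compound 2 `c1coc(CN2CCN(CCCc3c[nH]c4ccc(-n5cnnc5)cc34)CC2)c1` gives 0.4 nM in this assay, and the step of no change at the digits printed from compound 1 to compound 2 (within the scatter). Compound 3 `NC(=O)C(c1ccccc1)N1CCN(CCCc2c[nH]c3ccc(-n4cnnc4)cc23)CC1` gives 0.2 nM in this assay; it holds the lowest of the three numbers, yet both other compounds sit within the scatter of it, as seen in a 2.0-fold lower number from compound 1 to compound 3 (0.30 log units; within the scatter) and in a 2.0-fold lower number from compound 2 to compound 3 (0.30 log units; within the scatter). Compound 4 `CN(C)C(=O)C(c1ccccc1)N1CCN(CCCc2c[nH]c3ccc(-n4cnnc4)cc23)CC1` has not yet been measured. It differs from compound 3 in one place: dimethylamino in place of amino on a carbonyl carbon. Among the measured compounds shown here, none of the measured steps touches the carbamoyl group; the three steps change only the group on the ring amine nitrogen, and none of them moved the number beyond the scatter. The data therefore give no sign that a change in this outer part of the molecule shifts this assay, and no step beyond the scatter is expected for compound 4. The estimate for compound 4 in this assay is 0.3 nM, expected to lie between 0.1 nM and 1 nM, which amounts to an expected step of a 1.5-fold higher number from compound 3 to compound 4 (0.18 log units; within the scatter) that stays within the scatter.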

Compound 4, half-maximal inhibitory concentration: 1 nM
Estimate against measurement, compound 4: 3.3-fold (0.52 log units) below; low and high end bracket the measured number.
By their numbers in this assay, from the lowest: compounds 3, 1 and 2 (each within the scatter of the next); then compound 4.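

Among the compounds shown here, replacing amino with dimethylamino on a carbonyl carbon is the only step so far in this assay that lies beyond the scatter (a 5.0-fold higher number from compound 3 to compound 4 (0.70 log units; beyond the scatter)), and the step is modest. For the compounds shown here, the earlier steps all changed the group on the ring amine nitrogen, so this result is the first to show that the number responds to a change at the carbamoyl group, which the earlier compounds left untouched. The change also alters two counted features at once, as amino carries a hydrogen-bond donor and a single heavy atom while dimethylamino carries no donor and more heavy atoms, and nothing measured on these compounds explains the step.

The compounds shown leave open whether the loss of the donor or the added carbon atoms matter here, a question that methylamino on the same carbonyl carbon could help to separate. They also leave open how this position would respond to a carboxylic acid in place of the carbamoyl group, or to a pyrrolidin-1-yl group in place of the dimethylamino.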